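The source may hold more compounds than are shown below. What is called first, only, known or untested is meant among the compounds shown, and "the series" means these compounds.

Compound 2 `Cc1cc(C(=O)O)nn1Cc1cc(Cl)ccc1OCc1ccc(F)cc1F` carries the same core as compound 1 `Cc1cc(C(=O)O)nn1Cc1cc(Cl)ccc1OCc1ccc(Cl)cc1Cl`, the two differing only in the benzyl ether. In an assay on CHO-K1 cells for displacement of a labelled ligand from prostaglandin E2 receptor EP1 subtype (Homo sapiens) (on this read-out lower numbers stand for stronger inhibition and higher numbers for weaker inhibition), compound 1 gives only a limit, < 2000 nM. In this assay compound 2 likewise gives only a limit, < 2000 nM. The step that the two limits leave unreadable from compound 1 to compound 2 therefore cannot be sized, since both values sit at the limit of < 2000 nM in this assay, at which 2 of the 2 values shown sit. Compound 3 `Cc1cc(C(=O)O)nn1Cc1cc(F)ccc1OCc1ccc(F)cc1F` differs from compound 2 by fluoro in place of chloro on an aromatic carbon. Going by the values given here, no measured step reports this change, and the only related step is unreadable, so no direction is expected beyond the scatter. The step that the limit leaves unreadable from compound 2 to compound 3 is thus estimated as essentially flat. Compound 3 is expected to give about 500 nM, between 50 nM and 2000 nM.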

Compound 3, half-maximal inhibitory concentration: < 2000 nM
Compound 3: no number, only a limit; the forecaster's own chance of this, stated with the estimate: 60%; the middle value lies beyond the limit too.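

Compound 3, like compound 2, gives only a limit, so no step between them can be read: the limit of < 2000 nM in this assay, at which 3 of the 3 values shown sit.

The compounds shown leave open the actual values of compound 1, compound 2 and compound 3 in this assay, and so whether either exchange of groups changes anything.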